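Adding a Methoxy to the Anilide Ring of a Cinnamamide

This account rests on a few compounds, and the source may have more. Where it says the series, first, only, none or still open, it means among the compounds named here.

Measured compounds:
Compound 1, `COc1ccc(C(=O)c2cc(OC)c(OC)c(OC)c2)cc1NC(=O)/C=C/c1ccc(F)cc1`, 3900 nM
Compound 2, `COc1ccc(C(=O)c2cc(OC)c(OC)c(OC)c2)cc1NC(=O)/C=C/c1cccc(OC(F)(F)F)c1`, 10200 nM

In a functional assay on DU-145 cells (Homo sapiens) for cytotoxicity, read by MTT assay, with a stated time of 72 h (a lower number here means a stronger inhibitor, a higher number a weaker inhibitor), compound 1 stands with the lowest of the two numbers. For the measured compounds named here, its only neighbour is compound 2, and the single measured step, a 2.6-fold higher number from compound 1 to compound 2 (0.42 log units; beyond the scatter), changes the aryl group on the double-bonded chain carbon of the cinnamamide, not the core of compound 1.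

Compound 3, `COc1cc(C(=O)c2cc(OC)c(OC)c(OC)c2)cc(NC(=O)/C=C/c2ccc(F)cc2)c1OC`, differs from compound 1 by methoxy in place of hydrogen on an aromatic carbon. Going by the values given here, no measured step touches this position, so the change from compound 1 to compound 2 says nothing direct about it. With the shared core otherwise untouched, no shift beyond the usual scatter is expected. For compound 3 the expected step is therefore a 1.1-fold higher number from compound 1 to compound 3 (0.03 log units; within the scatter). Compound 3 is thus estimated at 4200 nM in this assay, with a range from 1500 nM to 12000 nM.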

Compound 3, half-maximal inhibitory concentration: 6700 nM
Beside the measured number, compound 3's estimate is 1.6-fold (0.20 log units) below it; measured number inside the range.
By their numbers in this assay, from the lowest: compounds 1, 3 and 2 (each within the scatter of the next, the first and the last beyond it).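

In this assay, methoxy in place of hydrogen on the aromatic carbon ortho to a methoxy group gives a 1.7-fold higher number from compound 1 to compound 3 (0.24 log units; within the scatter). For the compounds shown here, this is the first reading at a position that the earlier step did not touch, and it shows that the added methoxy leaves the number within the scatter of compound 1, at least with the 4-fluorophenyl group in place. Nothing available bears on the reason for the size of this step.

Still open, as far as these compounds go, is whether this methoxy would give a similar step when paired with the 3-(trifluoromethoxy)phenyl group of compound 2. Also open, from the compounds shown here alone, is what an amine, a hydroxy group or a longer alkoxy chain would do on the same aromatic carbon.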